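Methoxy for Methyl on the Sulfonate Ester Phenyl Ring

The source may report more compounds than this note shows. Statements on the series, on what has been measured and on what is new or still open speak of the compounds shown alone.

Compound 1 `CCCN1CCN(c2ccc(S(=O)(=O)Oc3ccccc3C)cc2)C1=O`: in a functional assay on HT-29 cells (Homo sapiens) for antiproliferative activity, read by sulforhodamine B assay, with a stated time of 48 h (a lower number here means a stronger inhibitor, a higher number a weaker inhibitor), compound 1 gives > 100000 nM, a limit of the assay and not a number.
Compound 2 `CCCN1CCN(c2ccc(S(=O)(=O)Oc3ccccc3OC)cc2)C1=O`: in this assay compound 2 gives > 100000 nM, again a limit rather than a number.
Compound 3 `CCCN1CCN(c2ccc(S(=O)(=O)Oc3ccc(C)cc3)cc2)C1=O`: in this assay compound 3 gives 25000 nM.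

All three share a core and differ only in the ring attached to the sulfonate oxygen. Compound 1 and compound 3 are built from the same atoms joined differently: 4-methylphenyl in place of 2-methylphenyl on an oxygen. This change brings an at least 4.0-fold lower number from compound 1 to compound 3 (0.60 log units; beyond the scatter), and the same kind of comparison brings an at least 4.0-fold lower number from compound 2 to compound 3 (0.60 log units; beyond the scatter). The step that the two limits leave unreadable from compound 1 to compound 2 cannot be sized because of the limit of > 100000 nM in this assay, at which 2 of the 3 values shown sit.

Compound 4 `CCCN1CCN(c2ccc(S(=O)(=O)Oc3ccc(OC)cc3)cc2)C1=O` has not yet been measured. It differs from compound 3 by methoxy in place of methyl on an aromatic carbon. This is the same kind of change as methoxy in place of methyl on an aromatic carbon, but not the same: in compound 2 the methoxy sits ortho to a large group, whereas in compound 4 it sits para to a large group. For the measured compounds named here, the one measured example of this change therefore gives no readable size, and the new setting around the place adds further uncertainty.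

Compound 4 is expected to give about 35000 nM, most likely between 10000 nM and 120000 nM. The expected step is a 1.4-fold higher number from compound 3 to compound 4 (0.15 log units; within the scatter), and it rests on compound 3 giving 25000 nM together with the unreadable step that the two limits leave unreadable from compound 1 to compound 2.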

Compound 4, half-maximal inhibitory concentration: 16000 nM
Beside the measured number, compound 4's estimate is 2.2-fold (0.34 log units) above it; measured number inside the range.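

In this assay, methoxy in place of methyl, para to a large group, brings a 1.6-fold lower number from compound 3 to compound 4 (0.19 log units; within the scatter), so at this place the change does not separate the two compounds. The same change on the 2-methylphenyl ring, from compound 1 to compound 2, cannot be sized, because both compounds sit at a limit of the assay and not at a number: the limit of > 100000 nM in this assay, at which 2 of the 4 values shown sit. This leaves one readable example of the change, which does not show whether the result carries to another setting or another core, while the clearer differences come with the 4-substituted rings and rest on those limits: an at least 6.2-fold lower number from compound 2 to compound 4 (0.79 log units; beyond the scatter), and an at least 6.2-fold lower number from compound 1 to compound 4 (0.79 log units; beyond the scatter).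

All four compounds shown keep the same core with its propyl chain, so how this change behaves on a different core remains untested here. Going by these compounds, it also remains open whether an amine or a carboxylic acid in place of the methoxy group, or a longer chain in place of the propyl chain, would give a step beyond the scatter.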